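This account rests on a few compounds, and the source may have more. Where it says the series, first, only, none or still open, it means among the compounds named here.

Measured compounds:
compound 1 `N#Cc1cnc(NCc2cnccc2C(F)(F)F)cc1N[C@H]1C[C@@H](O)C1` — > 10000 nM
compound 2 `CC1(C)C[C@H](Nc2nc(NCc3cnccc3C(F)(F)F)ncc2C#N)CC[C@@H]1O` — 800 nM
compound 3 `CC1(C)[C@@H](O)C[C@H]1Nc1nc(NCc2cnccc2C(F)(F)F)ncc1C#N` — 600 nM

For the measured compounds named here, in an assay on isolated protein for inhibition of protein kinase C delta type (Homo sapiens), read by TR-FRET, with a stated time of 2 h (a higher number here means a weaker inhibitor, a lower number a stronger inhibitor), compound 1 reaches only the limit of the measurement, > 10000 nM, so no number is known for it; it is the one compound that sits at the limit of > 10000 nM in this assay, at which 1 of the 3 values shown sits. Going by the values given here, compounds 2 and 3 share a core that differs from that of compound 1, and in this assay compound 2 gives 800 nM while compound 3 gives 600 nM; the one measured step, a 1.3-fold lower number from compound 2 to compound 3 (0.12 log units; within the scatter), is within the scatter.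

Compound 4 `CC1(C)[C@@H](Nc2cc(NCc3cnccc3C(F)(F)F)ncc2C#N)C[C@@H]1C(N)=O` is the unmeasured compound. It differs from compound 1 by 3-carbamoyl-2,2-dimethylcyclobutyl in place of 3-hydroxycyclobutyl on a nitrogen on an aromatic ring. Among the compounds with values here, no measured step runs from compound 1 to any other compound, and the step from compound 2 to compound 3 concerns a different core and a different exchange, so it bears on this change only loosely. Since compound 1 itself shows only a limit, the size of the step in this assay cannot be set from the data; a number below the limit is possible but not assured.

Compound 4 is therefore estimated at 5000 nM, within a range of 1500 nM to 20000 nM. The expected step is an at least 2.0-fold lower number from compound 1 to compound 4 (0.30 log units; that floor lies within the scatter), an estimate rather than a measured value.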

Compound 4, half-maximal inhibitory concentration: > 10000 nM
Compound 4: no number, only a limit; the forecaster's own chance of this, stated with the estimate: 35%; middle value at least 2.0-fold (0.30 log units) away from the limit.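

In this assay compound 4 gives > 10000 nM, which is a limit and not a number. Compound 1 also shows only a limit, and the step from compound 1 to compound 4 cannot be read. The compounds shown leave open whether 3-carbamoyl-2,2-dimethylcyclobutyl or 3-hydroxycyclobutyl gives the lower number on this core in this assay.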